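A few compounds are considered here, and "the series" means these few. Any claim that something is new, unique, unknown or untested is made for them only; others in the source may bear on it.

For the measured compounds named here, compound 2 `NS(=O)(=O)c1cc(-c2nnc(/C=C/c3ccc(Cl)cc3)o2)c(Cl)cc1SCc1ccccc1` stands at the lower end of the two numbers so far: in a functional assay on MCF7 cells (Homo sapiens) for cytotoxicity, read by MTT assay, with a stated time of 72 h (a lower number here means a stronger inhibitor, a higher number a weaker inhibitor), compound 2 gives 11000 nM, while compound 1 `NC(=O)c1cn(Cc2nnc(-c3cc(S(N)(=O)=O)c(SCc4ccccc4)cc3Cl)o2)nn1` gives 78000 nM. Going by the values given here, the only measured step is a 7.1-fold lower number from compound 1 to compound 2 (0.85 log units; beyond the scatter), which swaps the whole group on the shared core rather than a substituent on the pendant ring.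

Compound 3 `NS(=O)(=O)c1cc(-c2nnc(/C=C/c3c(Cl)cccc3Cl)o2)c(Cl)cc1SCc1ccccc1` differs from compound 2 by 2,6-dichlorophenyl in place of 4-chlorophenyl on a double-bonded chain carbon bound to a double-bonded chain carbon. Among the compounds with values here, no measured step bears on a chlorine pattern change within that phenyl ring; the one available step, a 7.1-fold lower number from compound 1 to compound 2 (0.85 log units; beyond the scatter), concerns a different part of the molecule and gives no guide to direction here. In this assay the step from compound 2 to compound 3 is therefore expected to stay within the scatter, neither clearly stronger nor weaker, with wide uncertainty. The expected step is no change at the digits printed from compound 2 to compound 3 (within the scatter). For compound 3 the estimate is 11000 nM, with a range from 3500 nM to 35000 nM.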

Compound 3, half-maximal inhibitory concentration: 29000 nM
For compound 3 the middle estimate is 2.6-fold (0.42 log units) below the measured one, within the range that was stated.
By their numbers in this assay, from the lowest: compound 2; then compound 3; then compound 1.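

In this assay, the aryl group on the ethenyl chain does affect the read-out: 2,6-dichlorophenyl in place of 4-chlorophenyl gives a 2.6-fold higher number from compound 2 to compound 3 (0.42 log units; beyond the scatter), so this position responds to a change in chlorine substitution. The 2-(2,6-dichlorophenyl)ethenyl group still compares favourably with (4-carbamoyl-1H-1,2,3-triazol-1-yl)methyl, with a 2.7-fold lower number from compound 1 to compound 3 (0.43 log units; beyond the scatter), so both ethenyl compounds lie below compound 1 and neither goes against that order. Nothing measured here accounts for the step between the two chlorine patterns.

This step changes the number of chlorines and their pattern together, so the two contributions cannot be separated. As far as these compounds go, it remains open whether 2-chlorophenyl, unsubstituted phenyl or 4-methoxyphenyl at this place would stay near compound 2 or move towards compound 3.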